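Removing the second sulfonamide from compound 2

The compounds below may be only part of what the source reports. "The series", "measured", "known", "first", "only" and "open" are said of these compounds alone.

Going by the values given here, compound 2 `CS(=O)(=O)Nc1ccc(-c2nc3cc(NS(=O)(=O)c4ccc(Cl)s4)ccc3o2)cc1` gives 43000 nM in an assay on cells for inhibition of HSP60/HSP10 (Homo sapiens), with a stated time of 60 min (on this read-out lower numbers stand for stronger inhibition and higher numbers for weaker inhibition), the only plain number among the two values here. Compound 1 `Cc1ccc(S(=O)(=O)Nc2ccc(-c3nc4ccccc4o3)cc2)cc1` sits at a limit of this assay, > 100000 nM. That limit is the limit of > 100000 nM in this assay, at which 1 of the 2 values shown sits. Compound 3 `CS(=O)(=O)Nc1ccc(-c2nc3ccccc3o2)cc1` has not yet been measured; it differs from compound 2 by hydrogen in place of ((5-chlorothiophen-2-yl)sulfonyl)amino on an aromatic carbon. Among the compounds with values here, no measured step of this kind exists here. The expected step is a 2.3-fold higher number from compound 2 to compound 3 (0.37 log units; beyond the scatter), toward weaker inhibition and beyond the usual scatter. Compound 3 is therefore estimated at 100000 nM, between 30000 nM and 300000 nM, with a real chance that this assay reports only a limit.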

Compound 3, half-maximal inhibitory concentration: > 100000 nM
Compound 3: no number, only a limit; the forecaster's own chance of this, stated with the estimate: 55%; the middle value lies on the limit itself.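

In this assay, hydrogen in place of ((5-chlorothiophen-2-yl)sulfonyl)amino on the aromatic carbon gives an at least 2.3-fold higher number from compound 2 to compound 3 (0.36 log units; beyond the scatter). On these data alone, compound 3 shows only a limit of the assay, > 100000 nM, so the true size of the loss stays unknown, but the group is needed here for any plain number in this set. The step between compound 1 and compound 3 cannot be read, since both sit at the same limit: the limit of > 100000 nM in this assay, at which 2 of the 3 values shown sit.

As far as these compounds go, it remains open how much of the group matters. A plain amine on that carbon, or the same sulfonylamino group without its chlorine, could show this.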